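The source may hold more compounds than are shown below. What is called first, only, known or untested is meant among the compounds shown, and "the series" means these compounds.

Compounds measured so far:
Compound 1, `C[C@H](NC(=O)c1cc(F)cc2cc(-c3ccc(Cl)cc3)oc12)C(=O)O`, 4440 nM
Compound 2, `O=C(NC1(C(=O)O)CCCC1)c1cc(F)cc2cc(-c3ccc(Cl)cc3)oc12`, 99 nM

In an assay on isolated protein for inhibition of endoplasmic reticulum aminopeptidase 1 (Homo sapiens), with stated times of 15 min and 20 min (a lower number here means a stronger inhibitor, a higher number a weaker inhibitor), compound 2 gives the lowest of the two numbers; the nearest is compound 1, and the step of a 45-fold lower number from compound 1 to compound 2 (1.65 log units; beyond the scatter) is large. Compound 3, `CN(C(=O)c1cc(F)cc2cc(-c3ccc(Cl)cc3)oc12)C(C)(C)C(=O)O`, differs from compound 2 in one place: (1-carboxy-1-methylethyl)(methyl)amino in place of (1-carboxycyclopentyl)amino on a carbonyl carbon. Among the measured compounds shown here, the only step that bears on this change is the one from compound 1 to compound 2, which shows how much the substituent on the amide nitrogen can move this assay. Compound 3 gives up the ring of compound 2 and also the amide hydrogen; the estimate for compound 3 is therefore a weaker number, about 1500 nM, with a range from 300 nM to 7000 nM, which would mean a step of a 15-fold higher number from compound 2 to compound 3 (1.18 log units; beyond the scatter).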

Compound 3, half-maximal inhibitory concentration: 1970 nM
Estimate against measurement, compound 3: 1.3-fold (0.12 log units) below; low and high end bracket the measured number.
By their numbers in this assay, from the lowest: compound 2; then compound 3; then compound 1.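

In this assay, the (1-carboxy-1-methylethyl)(methyl)amino group does not keep the gain seen with (1-carboxycyclopentyl)amino, with a 20-fold higher number from compound 2 to compound 3 (1.30 log units; beyond the scatter) on losing the ring and the amide hydrogen together. Against the (1-carboxyethyl)amino group, there remains only a 2.3-fold lower number from compound 1 to compound 3 (0.35 log units; beyond the scatter) in favour of the new group. No measurement at hand accounts for these steps.

The compounds shown do not separate the ring from the amide hydrogen, leaving open how a plain (1-carboxy-1-methylethyl)amino group would compare. Also open, from the compounds shown here alone, is how a carboxycyclohexyl group, or a primary amide in place of the carboxylic acid, would behave.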